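The source may hold more compounds than are shown below. What is called first, only, known or untested is meant among the compounds shown, and "the series" means these compounds.

Two close relatives of one shared core open this comparison. Compound 1, `Cn1c(=O)c2nc(-c3ccc(Cl)cc3)[nH]c2n(C)c1=O`, carries a chloro group on its outer aromatic ring, and in an assay for binding affinity to adenosine receptor A1 (Bos taurus) (on this read-out higher numbers stand for weaker inhibition and lower numbers for stronger inhibition), compound 1 gives 0.8 nM. Compound 2, `CCc1ccc(-c2nc3c(=O)n(C)c(=O)n(C)c3[nH]2)cc1`, carries an ethyl group in that same place, and in this assay compound 2 gives 0.8 nM. The step between them, ethyl in place of chloro on an aromatic carbon, reads no change at the digits printed from compound 1 to compound 2 (within the scatter), so compound 2 stands level with compound 1 within the usual scatter.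

Compound 3, `Cc1ccc(-c2nc3c(=O)n(C)c(=O)n(C)c3[nH]2)cc1`, has not yet been measured. It differs from compound 2 by hydrogen in place of methyl on a saturated chain carbon bound to an aromatic carbon, which, cut one bond further out, reads ethyl to methyl. For the measured compounds named here, only the step from compound 1 to compound 2 bears on this, and it showed no change beyond the scatter when a group of similar size was swapped at this position. The expected step is therefore small, a 1.1-fold higher number from compound 2 to compound 3 (0.05 log units; within the scatter), with no clear direction. On that basis compound 3 is estimated to give 0.9 nM in this assay, within a range from 0.3 nM to 2.7 nM.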

Compound 3, half-maximal inhibitory concentration: 0.8 nM
Compound 3: the middle estimate sits 1.1-fold (0.05 log units) above what was measured; the range from low to high includes it.
By their numbers in this assay, from the lowest: compounds 1, 2 and 3 (each within the scatter of the next).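

In this assay, cutting the ethyl group back to methyl, with hydrogen in place of methyl on a saturated chain carbon bound to an aromatic carbon, reads no change at the digits printed from compound 2 to compound 3 (within the scatter) and so adds a change of chain length to the earlier swap of one group for another. Methyl in place of chloro on an aromatic carbon reads no change at the digits printed from compound 1 to compound 3 (within the scatter) and so gives a second comparison with the chloro compound, which means that chloro, ethyl and methyl, the three groups seen at this place, all lie within the scatter of one another in this read-out. Nothing available here accounts for why these three groups read alike.

From the compounds shown here alone, what stays open is how far this tolerance extends, since three groups mark out only a small part of what could sit on that aromatic carbon. A longer chain such as butyl, an amine or a carboxylic acid at this place could read level with these compounds or could move the number clearly away from them, and the three values here cannot tell which.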